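A Hydroxyphenyl Sulfonamide Expected to Stay Non-Toxic

The source may hold more compounds than are shown below. What is called first, only, known or untested is meant among the compounds shown, and "the series" means these compounds.

This account follows the step from compound 1 `O=S(=O)(Nc1ccc(-c2nc3ccccc3o2)cc1)c1cccs1` to compound 4 `O=S(=O)(Nc1ccc(-c2nc3ccccc3o2)cc1)c1ccc(O)cc1` in an ADME assay on HEK293 cells (Homo sapiens) for cytotoxicity, read by resazurin assay, with a stated time of 48 h; on this read-out lower numbers stand for higher toxicity in this test and higher numbers for lower toxicity in this test. In this assay compound 1 gives only a limit, > 100000 nM, and not a number. Two further compounds on a related core were measured alongside it. Compound 2 `O=S(=O)(Nc1ccc2oc(-c3ccccc3)nc2c1)c1ccc(Cl)c(Cl)c1` gives 71000 nM in this assay. Compound 3 `O=S(=O)(Nc1ccc2oc(-c3ccccc3)nc2c1)c1ccc(F)c(C(F)(F)F)c1` gives only a limit, > 100000 nM, in this assay. Among the compounds with values here, compound 1 therefore stands at the limit of > 100000 nM in this assay, at which 2 of the 3 values shown sit, the top of what this measurement can report, and the one numeric value, from compound 2, is the only number in the set. Within the data shown here, no step between two measured compounds is available, so nothing measured speaks to how the change from compound 1 to compound 4 should act. The change itself is 4-hydroxyphenyl in place of thiophen-2-yl on a sulfonyl sulfur.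

Among the measured compounds shown here, with compound 1 at the limit and no measured step to lean on, the step of a number no higher from compound 1 to compound 4 (the limit leaves the size open) is expected to be none beyond the scatter. Compound 4 is therefore expected to give 100000 nM, within a range from 50000 nM to 200000 nM, with a real chance that the measurement again reports only a limit rather than a number.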

Compound 4, half-maximal cytotoxic concentration: > 100000 nM
Compound 4: no number, only a limit; the forecaster's own chance of this, stated with the estimate: 65%; the middle value lies on the limit itself.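

In this assay compound 4 gives > 100000 nM, which is a limit and not a number. Within the data shown here, compound 1 also gives only a limit, so no step between compound 1 and compound 4 can be read. The compounds shown leave open whether 4-hydroxyphenyl in place of thiophen-2-yl on a sulfonyl sulfur changes this read-out at all.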